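One more methyl on the aromatic ring of compound 2

This account rests on a few compounds, and the source may have more. Where it says the series, first, only, none or still open, it means among the compounds named here.

- Compound 1 `O=C1C(Nc2ccc(I)cc2)=CC(=O)c2c1nc1n2[C@H]2OC[C@@H](O)[C@H]2OC1` gives 3890 nM
- Compound 2 `Cc1ccc(NC2=CC(=O)c3c(nc4n3[C@H]3OC[C@@H](O)[C@H]3OC4)C2=O)cc1` gives > 4000 nM (a limit)
- Compound 3 `Cc1ccc(NC2=CC(=O)c3c(nc4n3[C@H]3OC[C@@H](O)[C@H]3OC4)C2=O)cc1C` is not yet measured

In a functional assay on MCF7 cells (Homo sapiens) for inhibition, read by sulforhodamine B assay (on this read-out higher numbers stand for weaker inhibition and lower numbers for stronger inhibition), compound 2 reads > 4000 nM as a limit and not as a number. Where compound 2 stands is given by the limit of > 4000 nM in this assay, at which 1 of the 2 values shown sits, alone.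

Going to compound 3 brings one change, methyl in place of hydrogen on an aromatic carbon. Within the data shown here, the only measured step on this aromatic ring is an at least 1.0-fold higher number from compound 1 to compound 2 (0.01 log units; that floor lies within the scatter) and, as it ends at a limit, it gives a floor and no true size. From that step, no change beyond the scatter is expected in this assay and no direction can be named. The estimated step is a step that the limit leaves unreadable from compound 2 to compound 3. The expected outcome for compound 3 may well be only a limit. Compound 3 is estimated at 5000 nM with an expected range from 2500 nM to 10000 nM.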

Compound 3, half-maximal inhibitory concentration: 4950 nM
Compound 3: the middle estimate sits 1.0-fold (0.00 log units) above what was measured, and the stated range covers the measured number.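

Unlike compound 2, compound 3 has a true number in this assay, so a ring carrying two methyl groups can be placed on the scale. Against the iodo compound, the result is a 1.3-fold higher number from compound 1 to compound 3 (0.10 log units; within the scatter), so 3,4-dimethylphenyl and 4-iodophenyl on the amine nitrogen cannot be told apart in this assay. The effect of the added methyl, ortho to the first methyl, cannot be read, because compound 2 is held only by a limit: the limit of > 4000 nM in this assay, at which 1 of the 3 values shown sits.

From the compounds shown here alone, it remains open whether that added methyl changes the number at all. Going by these compounds, it is also open whether a different group on this ring, such as a methoxy group, an amine or a carboxylic acid, would shift the number beyond the scatter of repeated measurements.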